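The source may report more compounds than this note shows. Statements on the series, on what has been measured and on what is new or still open speak of the compounds shown alone.

Working notes on the side chains carried by the shared core. In an ADME assay on microsomes from liver (Homo sapiens) for metabolic stability, using NADPH, with a stated time of 60 min, in the presence of a further agent that is not named here (a higher number here means faster removal of the compound, a lower number slower removal), compound 1 (`O=C(O)CNC(=O)COc1ccc([C@H]2CC[C@]3(CC2)OOC2(O3)C3CC4CC(C3)CC2C4)cc1`) gives < 7 mL.min-1.g-1 as a limit of the assay, not a number. Compound 2 (`O=C(O)CCCCOc1ccc([C@H]2CC[C@]3(CC2)OOC2(O3)C3CC4CC(C3)CC2C4)cc1`) gives < 7 mL.min-1.g-1 as a limit too. Compound 3 (`CC(C)(Oc1ccc([C@H]2CC[C@]3(CC2)OOC2(O3)C3CC4CC(C3)CC2C4)cc1)C(=O)O`) gives < 7 mL.min-1.g-1 as a limit as well. The position of compound 3 is therefore shared with the other two, and no rank can be read among them: the limit of < 7 mL.min-1.g-1 in this assay, at which 3 of the 3 values shown sit, is all that the numbers show.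

The next change leads to compound 4 (`O=C(O)CCCOc1ccc([C@H]2CC[C@]3(CC2)OOC2(O3)C3CC4CC(C3)CC2C4)cc1`), and it is 3-carboxypropyl in place of 1-carboxy-1-methylethyl on an oxygen on an aromatic ring with 3-carboxypropyl in place of 1-carboxy-1-methylethyl on an oxygen on an aromatic ring. The closest measured comparison is a step that the two limits leave unreadable from compound 2 to compound 3 and it swaps 4-carboxybutyl for the same 1-carboxy-1-methylethyl on that oxygen. The other two, a step that the two limits leave unreadable from compound 1 to compound 2 and a step that the two limits leave unreadable from compound 1 to compound 3, give no size either.

All three side chains sit at the same limit, so no step beyond the usual scatter is expected in this assay and no direction can be assigned. The expected change is a step that the limit leaves unreadable from compound 3 to compound 4 and it rests on the limit of compound 2 at < 7 mL.min-1.g-1 as the nearest side chain. For compound 4 the estimated value is 5 mL.min-1.g-1 with an expected range of 3 mL.min-1.g-1 to 9 mL.min-1.g-1 and a report as a limit is the likely form.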

Compound 4, intrinsic clearance in microsomes: < 7 mL.min-1.g-1
Compound 4: a limit, no number; the forecaster's own chance of this, stated with the estimate: 85%; the middle value lies beyond the limit too.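

In this assay compound 4 gives < 7 mL.min-1.g-1, a limit of the assay and not a number. Its steps from compound 1, compound 2 and compound 3 therefore cannot be read: the limit of < 7 mL.min-1.g-1 in this assay, at which 4 of the 4 values shown sit. The compounds shown leave open whether these side chains differ at all in intrinsic clearance in microsomes, and how they would rank.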